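A few compounds are considered here, and "the series" means these few. Any claim that something is new, unique, unknown or untested is made for them only; others in the source may bear on it.

Compound 1, `COc1ccc(-c2cc(/C=C/C(=O)c3ccc(N)cc3)[nH]n2)cc1`: -7%
Compound 2, `COc1cc(-c2cc(/C=C/C(=O)c3ccc(N)cc3)[nH]n2)cc(OC)c1OC`: 7%

In a functional assay on MDA-MB-231 cells (Homo sapiens) for cytotoxicity, read by sulforhodamine B assay, with a stated time of 48 h, tested at 10 uM (on this read-out lower numbers stand for a stronger effect and higher numbers for a weaker effect at the one concentration tested), compound 2 gives 7%, the highest of the two numbers. In this assay compound 1 gives -7%, a lower number, and that gap lies beyond the scatter. Compound 3, `COc1ccc(-c2cc(/C=C/C(=O)c3ccc(N)cc3)[nH]n2)cc1OC`, differs from compound 2 by hydrogen in place of methoxy on an aromatic carbon. Among the measured compounds shown here, no step between measured compounds is known, so the expected step of a number 6 percentage points lower from compound 2 to compound 3 (within the scatter) is judged only from the two values: a small fall, likely within the scatter, is expected. Compound 3 is estimated at 1%, between -14% and 16%.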

Compound 3, a percentage reported as activity, at one concentration (the size of the read-out at that concentration, not a potency): 24%
Compound 3: the middle estimate sits 23 percentage points below what was measured; the measured number lies above the stated range.
By their numbers in this assay, from the lowest: compound 1; then compound 2; then compound 3.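

In this assay, changes at the methoxy-bearing aromatic carbons do not run in one direction: hydrogen in place of methoxy gives a number 17 percentage points higher from compound 2 to compound 3 (beyond the scatter), while methoxy in place of hydrogen gives a number 31 percentage points higher from compound 1 to compound 3 (beyond the scatter). Both steps end at compound 3, the weakest of the three at the one concentration tested, so the outcome of the same exchange depends on the methoxy groups already on the ring. Nothing at hand explains this reversal. On these data alone, whether a hydroxy group or a fluorine atom on that aromatic carbon would behave like methoxy or like hydrogen remains open.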